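Three limits and a fourth anilino variant

A few compounds are considered here, and "the series" means these few. Any claim that something is new, unique, unknown or untested is made for them only; others in the source may bear on it.

Compound 2 `CC(C)c1ccc(-c2nc(SCc3cn(CC(=O)NC(=O)Nc4ccccn4)nn3)nc(Nc3cccc([N+](=O)[O-])c3)c2C#N)cc1` is the starting point of this step. In a functional assay on MGC-803 cells (Homo sapiens) for inhibition, read by MTT assay, with a stated time of 72 h (a lower number here means a stronger inhibitor, a higher number a weaker inhibitor), compound 2 gives only a limit, > 64000 nM, and no number. Compound 1 `CC(C)c1ccc(-c2nc(SCc3cn(CC(=O)NC(=O)Nc4ccccn4)nn3)nc(Nc3cccc(C(F)(F)F)c3)c2C#N)cc1` likewise stops at a limit in this assay, namely > 64000 nM. Compound 3 `COc1ccccc1Nc1nc(SCc2cn(CC(=O)NC(=O)Nc3ccccn3)nn2)nc(-c2ccc(C(C)C)cc2)c1C#N` also gives in this assay nothing but the limit > 64000 nM. Because every value shown sits at the limit of > 64000 nM in this assay, at which 3 of the 3 values shown sit, none of the three steps between the measured compounds can be read: a step that the two limits leave unreadable from compound 1 to compound 2, a step that the two limits leave unreadable from compound 1 to compound 3 and a step that the two limits leave unreadable from compound 2 to compound 3 all remain of unknown size. Compound 4 `CC(C)c1ccc(Nc2nc(SCc3cn(CC(=O)NC(=O)Nc4ccccn4)nn3)nc(-c3ccc(C(C)C)cc3)c2C#N)cc1` has not yet been measured. It differs from compound 2 by 4-isopropylphenyl in place of 3-nitrophenyl on a nitrogen on an aromatic ring. Going by the values given here, the steps that bear on this change are those among compounds 1, 2 and 3, and since each of them is hidden behind (the limit of > 64000 nM in this assay, at which 3 of the 3 values shown sit), they give neither a size nor a direction. With three unreadable steps and nothing else to go on, compound 4 is expected to stay at the limit as well, so that the step that the limit leaves unreadable from compound 2 to compound 4 is expected to be no more than a restatement of that limit. Compound 4 is therefore estimated at 80000 nM in this assay, within a range from 20000 nM to 320000 nM.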

Compound 4, half-maximal inhibitory concentration: 15800 nM
Compound 4: the middle estimate sits 5.1-fold (0.70 log units) above what was measured, outside the stated range (below it).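

Going by these compounds alone, at this position, the nitrogen on an aromatic ring, this assay now gives a readable change for the first time: 4-isopropylphenyl in place of 3-nitrophenyl gives an at least 4.0-fold lower number from compound 2 to compound 4 (0.60 log units; beyond the scatter). The same group gives an at least 4.0-fold lower number from compound 3 to compound 4 (0.60 log units; beyond the scatter), and it gives an at least 4.0-fold lower number from compound 1 to compound 4 (0.60 log units; beyond the scatter), so among the four groups shown on this nitrogen, 4-isopropylphenyl alone brings a value clear of the limit. The steps among compounds 1, 2 and 3 still cannot be read, and no order can be given for 3-nitrophenyl, 3-(trifluoromethyl)phenyl and 2-methoxyphenyl: the limit of > 64000 nM in this assay, at which 3 of the 4 values shown sit.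

On these data alone, whether the change depends on the isopropyl group itself or on its place on the ring stays open, and a 3-isopropylphenyl or a plain phenyl group on this nitrogen would speak to that. As far as these compounds go, it is equally open whether a longer chain in the same place, such as 4-butylphenyl, or a 4-aminophenyl or 4-carboxyphenyl group would keep, lower or lose the value of compound 4.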